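A few compounds are considered here, and "the series" means these few. Any claim that something is new, unique, unknown or untested is made for them only; others in the source may bear on it.

Three compounds of a shared core were measured in an ADME assay on HT-29 cells (Homo sapiens) for cytotoxicity, read by MTT assay, with a stated time of 72 h; on this read-out higher numbers stand for weaker inhibition and lower numbers for stronger inhibition. Compound 1 `COc1ccc(C2=C(c3cc(OC)c(OC)c(OC)c3)C(=O)C(OC(C)=O)C2)cc1OC(C)C` gave > 100 ug/mL, a limit of the assay rather than a number. Compound 2 `COc1ccc(C2=C(c3cc(OC)c(OC)c(OC)c3)C(=O)C(OC(C)=O)C2)cc1F` gave < 1 ug/mL, also a limit. Compound 3 `COc1ccc(C2=C(c3cc(OC)c(OC)c(OC)c3)C(=O)C(O)C2)cc1F` gave < 1 ug/mL, again a limit.

Two measured steps follow. Between compound 2 and compound 1 the change is isopropoxy in place of fluoro on an aromatic carbon, and it brought an at least 100-fold higher number from compound 2 to compound 1 (2.00 log units; beyond the scatter); the size comes from the limit of < 1 ug/mL in this assay, at which 2 of the 3 values shown sit, and (the limit of > 100 ug/mL in this assay, at which 1 of the 3 values shown sits), so only its lower bound is known. Between compound 2 and compound 3 the change is hydrogen in place of acetyl on an oxygen on a saturated carbon, and it brought a step that the two limits leave unreadable from compound 2 to compound 3.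

Compound 4 `COc1ccc(C2=C(c3cc(OC)c(OC)c(OC)c3)C(=O)C(O)C2)cc1OC(C)C` has not been measured. It differs from compound 3 by isopropoxy in place of fluoro on an aromatic carbon. This is the same change as that from compound 2 to compound 1, and the place is the same word for word; the two cores differ by the change already given as hydrogen in place of acetyl on an oxygen on a saturated carbon. Because of an at least 100-fold higher number from compound 2 to compound 1 (2.00 log units; beyond the scatter), the same change on the core of compound 3 is expected to give a step of about the same size, namely an at least 100-fold higher number from compound 3 to compound 4 (2.00 log units; beyond the scatter), though that rests on a single pair whose size is only bounded. Compound 4 is therefore expected to land near 100 ug/mL in this assay, likely reported again as a limit, within a range from 30 ug/mL to 300 ug/mL.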

Compound 4, half-maximal inhibitory concentration: > 100 ug/mL
Compound 4: a limit, no number; the forecaster's own chance of this, stated with the estimate: 75%; the middle value sits exactly at the limit.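

Isopropoxy in place of fluoro on an aromatic carbon brought an at least 100-fold higher number from compound 3 to compound 4 (2.00 log units; beyond the scatter) in this assay. The change therefore carried over from the core with the acetyl group on the oxygen to the core with hydrogen there, going the same way on both and beyond the scatter on both, and the two steps stand side by side as follows: the same change on two cores in this assay, an at least 100-fold higher number (2.00 log units; beyond the scatter) from compound 2 to compound 1 and an at least 100-fold higher number (2.00 log units; beyond the scatter) from compound 3 to compound 4; the limit leaves it open whether they differ. This does not show that the two steps are equal in size, and the steps that swap acetyl for hydrogen on that oxygen cannot be read, so the pairs shown say nothing about whether that swap alters the effect of the change on the aromatic carbon, as the higher values are limits rather than numbers: the limit of > 100 ug/mL in this assay, at which 2 of the 4 values shown sit.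

The compounds shown leave open how far the true values of compound 2 and compound 3 lie past their limit, and likewise those of compound 1 and compound 4, so the full size of the change stays unknown on both cores. They also leave open what happens on the same aromatic carbon with a group of another kind, such as chloro, ethoxy or an amine, which would show how the read-out runs between fluoro and isopropoxy.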